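Losing the phenyl group: what to expect of compound 3

A few compounds are considered here, and "the series" means these few. Any claim that something is new, unique, unknown or untested is made for them only; others in the source may bear on it.

In an ADME assay on Jurkat cells (Homo sapiens) for cytotoxicity, read by XTT assay (on this read-out higher numbers stand for lower toxicity in this test and lower numbers for higher toxicity in this test), compound 1 (`NC(=O)c1sc(N)nc1-c1cccc(I)c1`) stands as "not determined" (no result reported) and so offers no number for comparison. Among the measured compounds shown here, compound 2 (`NC(=O)c1sc(N)nc1-c1cccc(-c2ccccc2)c1`) gives 244000 nM as the only number available, which leaves it with no measured neighbour to be ranked against. Compound 3 (`NC(=O)c1sc(N)nc1-c1ccccc1`) has yet to be measured in this assay and differs from compound 2 by one change (hydrogen in place of phenyl on an aromatic carbon): hydrogen in place of phenyl on an aromatic carbon. For the measured compounds named here, no measured step between related compounds is available as a guide, so the expectation is loose: a modest move towards higher numbers, possibly not beyond the usual scatter. The expected change is a 1.6-fold higher number from compound 2 to compound 3 (0.21 log units; within the scatter) as an estimate. The estimated value for compound 3 is 400000 nM with 150000 nM to 1000000 nM as the expected range.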

Compound 3, half-maximal cytotoxic concentration: > 312000 nM
Compound 3 ended at the assay's limit (the forecaster's own chance of this, stated with the estimate: 35%); the middle value lies beyond the limit too.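

In this assay, compound 3 gives > 312000 nM, which is a limit of the assay and not a number. Putting hydrogen in place of phenyl on an aromatic carbon gives an at least 1.2-fold higher number from compound 2 to compound 3 (0.10 log units; that floor lies within the scatter), so the phenyl group of compound 2 is not needed for a number this high, and its loss brings no move towards lower numbers. As far as these compounds go, the step remains a floor, and its true size stays unknown, because compound 3 stands at a limit: the limit of > 312000 nM in this assay, at which 1 of the 3 values shown sits.

The iodine of compound 1 offers no comparison, since compound 1 stands as "not determined" (no result reported), so only phenyl and hydrogen can be set side by side at this position. From the compounds shown here alone, whether an amine or a carboxylic acid on the same carbon would bring the reading down from the limit stays open.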